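The source may hold more compounds than are shown below. What is called first, only, known or untested is meant among the compounds shown, and "the series" means these compounds.

Three compounds sharing one core were tested in an ADME assay on MDCK cells (Canis lupus familiaris) for cytotoxicity, read by microscopy, with a stated time of 48 h; on this read-out lower numbers stand for higher toxicity in this test and higher numbers for lower toxicity in this test. Compound 1 `Cc1ccsc1CN[C@@H]1C[C@H]2C[C@@H]([C@H]1C)C2(C)C` gives 10000 nM, compound 2 `C[C@H]1[C@H](NCc2ccc(Cl)s2)C[C@H]2C[C@@H]1C2(C)C` gives 25000 nM, and compound 3 `C[C@H]1[C@H](NCc2ccco2)C[C@H]2C[C@@H]1C2(C)C` gives 50000 nM. Compound 1 thus stands at the lowest of the three numbers: a 2.5-fold higher number from compound 1 to compound 2 (0.40 log units; beyond the scatter) and a 5.0-fold higher number from compound 1 to compound 3 (0.70 log units; beyond the scatter), while a 2.0-fold higher number from compound 2 to compound 3 (0.30 log units; within the scatter). Compound 4 `CCOc1ccsc1CN[C@@H]1C[C@H]2C[C@@H]([C@H]1C)C2(C)C` differs from compound 1 by ethoxy in place of methyl on an aromatic carbon. Going by the values given here, neither measured step bears closely on this change, as both exchange the whole ring group on the saturated chain carbon bound to an amine nitrogen rather than a group on that ring; they show only that changes in this region gave modest increases. A step of modest size upward, or none beyond the scatter, is therefore expected in this assay, as a 1.5-fold higher number from compound 1 to compound 4 (0.18 log units; within the scatter). Compound 4 is estimated to give 15000 nM, within 5000 nM to 50000 nM.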

Compound 4, minimum cytotoxic concentration: 50000 nM
Estimate against measurement, compound 4: 3.3-fold (0.52 log units) below; the range from low to high includes it.
By their numbers in this assay, from the lowest: compound 1; then compounds 2, 3 and 4 (each within the scatter of the next).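

In this assay, a change on the ring itself, and not only an exchange of the whole ring group, shifts the read-out: ethoxy in place of methyl on an aromatic carbon, next to the ring atom that bears a large group, gives a 5.0-fold higher number from compound 1 to compound 4 (0.70 log units; beyond the scatter). This position is therefore not silent in this test, and the step runs towards lower toxicity. Nothing shown gives a reason for this step.

Going by these compounds, what remains open is whether methoxy or a plain propyl chain at this position would give a similar step, which would separate the part played by the oxygen from that of the added length.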